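Swapping the basic amine tail in a cytotoxicity series

A few compounds are considered here, and "the series" means these few. Any claim that something is new, unique, unknown or untested is made for them only; others in the source may bear on it.

Measured compounds:
- compound 1, `COc1cc2c(Oc3ccc(NC(=O)c4cc(-c5ccccc5C)ccn4)cc3F)ccnc2cc1OCCCN1CCN(C)CC1`: 2030 nM
- compound 2, `COc1cc2c(Oc3ccc(NC(=O)c4cc(-c5ccc(F)cc5)ccn4)cc3F)ccnc2cc1OCCCN1CCN(C)CC1`: "not determined" (no result reported)
- compound 3, `COc1cc2c(Oc3ccc(NC(=O)c4cc(-c5ccccc5F)ccn4)cc3F)ccnc2cc1OCCCN1CCN(C)CC1`: "not determined" (no result reported)

Three close relatives were tested in a functional assay on U-87MG ATCC cells (Homo sapiens) for cytotoxicity, read by MTT assay, with a stated time of 72 h; on this read-out lower numbers stand for stronger inhibition and higher numbers for weaker inhibition. Compound 1 gives 2030 nM in this assay. For compound 2 this assay reports "not determined" (no result reported), and for compound 3 it likewise reports "not determined" (no result reported), so no number stands for either of them, and compound 2 cannot be placed against compound 1 on the figures shown. Among the compounds with values here, the only number in the set is that of compound 1.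

Compound 4, `COc1cc2c(Oc3ccc(NC(=O)c4cc(-c5ccc(F)cc5)ccn4)cc3F)ccnc2cc1OCCCN1CCCC1`, differs from compound 2 in one place: pyrrolidin-1-yl in place of 4-methylpiperazin-1-yl on a saturated chain carbon, three bonds along the chain from an oxygen on an aromatic ring. Within the data shown here, no measured pair in this set shows what such a change does, so its direction and size in this assay are not known from the data. With compound 2 itself lacking a number, the expectation for compound 4 can lean only on compound 1, whose value of 2030 nM is the sole anchor. Compound 4 is therefore expected to give about 2000 nM in this assay, with a wide range from 400 nM to 10000 nM.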

Compound 4, half-maximal inhibitory concentration: 1780 nM
Estimate against measurement, compound 4: 1.1-fold (0.05 log units) above; the range from low to high includes it.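

Compound 2 has no number to set against compound 4, so no step can be read between them. Nothing shown offers an explanation for the value of compound 4. Going by these compounds, what replacing 4-methylpiperazin-1-yl with pyrrolidin-1-yl does in this assay stays open.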